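Replacing the chlorophenyl of compound 3 with piperidin-4-yl

The source may hold more compounds than are shown below. What is called first, only, known or untested is meant among the compounds shown, and "the series" means these compounds.

compound 1 `c1ccc(-c2nc(-c3c[nH]c4ccccc34)co2)cc1`: 171000 nM
compound 2 `Oc1ccc(-c2nc(-c3c[nH]c4ccccc34)co2)cc1`: 103000 nM
compound 3 `Clc1ccc(-c2nc(-c3c[nH]c4ccccc34)co2)cc1`: 608000 nM

In a functional assay on MDA-MB-231 cells (Homo sapiens) for cytotoxicity, read by MTT assay, with a stated time of 48 h (a higher number here means a weaker inhibitor, a lower number a stronger inhibitor), compound 3 gives the highest of the three numbers: a 3.6-fold higher number from compound 1 to compound 3 (0.55 log units; beyond the scatter) and a 5.9-fold higher number from compound 2 to compound 3 (0.77 log units; beyond the scatter), both beyond the scatter, so compound 3 is the weakest inhibitor measured. Compound 4 `c1ccc2c(-c3coc(C4CCNCC4)n3)c[nH]c2c1` carries piperidin-4-yl in place of 4-chlorophenyl on an aromatic carbon. The steps from compound 1 and from compound 2 to compound 3 concern only a substituent on the 4-chlorophenyl, not its exchange for a non-aromatic ring, so they bear on this change only loosely; they show that one change on this part of the core moved this assay by modest amounts. A modest step of uncertain direction is therefore expected, a 2.4-fold lower number from compound 3 to compound 4 (0.39 log units; beyond the scatter), giving an estimated 250000 nM for compound 4, between 60000 nM and 1000000 nM.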

Compound 4, half-maximal inhibitory concentration: 528000 nM
The estimate for compound 4 lay 2.1-fold (0.32 log units) below the measured number, within the range that was stated.
By their numbers in this assay, from the lowest: compounds 2 and 1 (each within the scatter of the next); then compounds 4 and 3 (each within the scatter of the next).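

In this assay, exchanging the aromatic 4-chlorophenyl for the non-aromatic piperidin-4-yl made no difference beyond the scatter, with a 1.2-fold lower number from compound 3 to compound 4 (0.06 log units; within the scatter). So this position accepted a non-aromatic ring with a hetero atom as it accepted 4-chlorophenyl, but that ring did not match the phenyl or 4-hydroxyphenyl groups: a 3.1-fold higher number from compound 1 to compound 4 (0.49 log units; beyond the scatter) and a 5.1-fold higher number from compound 2 to compound 4 (0.71 log units; beyond the scatter). No supporting data explain these results. The compounds shown leave open whether a carboxylic acid or a longer chain ending in an amine at this position would lower the number. They also leave open whether a hydroxy on the piperidin-4-yl would do so.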